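Ether chain extension: two steps compared

This account rests on a few compounds, and the source may have more. Where it says the series, first, only, none or still open, it means among the compounds named here.

Compound 1 `CCCCCCCCCCCCOc1cc(OC)c(Br)cc1C(C)=O` and compound 2 `CCCCCCCCCCCCCCOc1cc(OC)c(Br)cc1C(C)=O` differ by ethyl in place of hydrogen on a saturated chain carbon, ten or more bonds along the chain from an oxygen on an aromatic ring. In a functional assay, with a stated time of 10 min (on this read-out higher numbers stand for weaker inhibition and lower numbers for stronger inhibition), compound 1 gives 23100000 nM and compound 2 gives 13200000 nM; the step between them is a 1.8-fold lower number from compound 1 to compound 2 (0.24 log units; within the scatter). Compound 3 `CCCCOc1cc(OC)ccc1C(C)=O` gives 57200000 nM in this assay, the highest of the three numbers. The difference between the core of compound 3 and the core of compound 1 is not broken down here. Compound 4 `CCCCCCOc1cc(OC)ccc1C(C)=O` differs from compound 3 by ethyl in place of hydrogen on a saturated chain carbon, four bonds along the chain from an oxygen on an aromatic ring. Going by the values given here, this is the same kind of change as the one between compound 1 and compound 2, not the same change: here it sits four bonds along the chain from an oxygen on an aromatic ring, which is not the place of the earlier change. Since the earlier step was a 1.8-fold lower number from compound 1 to compound 2 (0.24 log units; within the scatter), a similarly small step is expected, a 1.4-fold lower number from compound 3 to compound 4 (0.16 log units; within the scatter). Compound 4 is expected to give about 40000000 nM in this assay, within an estimated range from 20000000 nM to 80000000 nM.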

Compound 4, half-maximal inhibitory concentration: 84400000 nM
Estimate against measurement, compound 4: 2.1-fold (0.32 log units) below; measured number above the stated range.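

In this assay the ethyl change gives a 1.5-fold higher number from compound 3 to compound 4 (0.17 log units; within the scatter) and does not separate from the earlier step: the same change on two cores in this assay, a 1.8-fold lower number (0.24 log units; within the scatter) from compound 1 to compound 2 and a 1.5-fold higher number (0.17 log units; within the scatter) from compound 3 to compound 4, 2.6-fold (0.41 log units) apart, within the scatter of two such steps

Carried from one core to the other, at two different places on the chain, the change gives no step beyond the scatter on either core. This does not show that the change has no effect, and the opposite directions of the two steps cannot be read as a real difference between the cores. With one step per core, it also shows nothing about how the change behaves on other cores or at other places on the chain.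

Open, on these data alone, is whether an amine or a carboxylic acid in place of the ether chain would give a step beyond the scatter. Also open, as far as these compounds go, is whether a longer chain on the core of compound 3 would do so.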